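Methyl Steps on a Shared Core in a Whole-Animal Assay

This account rests on a few compounds, and the source may have more. Where it says the series, first, only, none or still open, it means among the compounds named here.

Of the compounds shown here, three built on one core have been measured in a functional assay for inhibition, with Rattus norvegicus as the target; a lower number here means a stronger inhibitor, a higher number a weaker inhibitor. Compound 1 `CC(/N=c1\c(O)c(O)\c1=N/Cc1ccc(C#N)cc1Cl)C(C)(C)C` gives 180 nM. Compound 2 `Cc1cc(C#N)cc(Cl)c1C/N=c1\c(O)c(O)\c1=N/C(C)C(C)(C)C` differs from compound 1 by methyl in place of hydrogen on an aromatic carbon. In this assay compound 2 gives 1900 nM, a step of an 11-fold higher number from compound 1 to compound 2 (1.02 log units; beyond the scatter). Compound 3 `CCC(C)(C)/N=c1\c(O)c(O)\c1=N/Cc1c(C)cccc1Cl` gives 4400 nM, the highest of the three numbers; the difference between the cores of compound 1 and compound 3 is not broken down here. Compound 4 `CCC(C)(C)/N=c1\c(O)c(O)\c1=N/Cc1c(C)cc(C)cc1Cl` is not yet measured; it differs from compound 3 by methyl in place of hydrogen on an aromatic carbon. This is the same kind of change as from compound 1 to compound 2, but at another place: there the methyl was ortho to a large group and meta to a chloro group and a cyano group, here it is meta to a chloro group, meta to a methyl group and para to a large group. Because the earlier step was an 11-fold higher number from compound 1 to compound 2 (1.02 log units; beyond the scatter) but sat at a different place, a smaller step of a 1.8-fold higher number from compound 3 to compound 4 (0.26 log units; within the scatter) is expected. Compound 4 is thus estimated at 8000 nM, between 2500 nM and 25000 nM.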

Compound 4, half-maximal inhibitory concentration: 200 nM
For compound 4 the middle estimate is 40-fold (1.60 log units) above the measured one; measured number outside the range, below it.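

In this assay, methyl in place of hydrogen on an aromatic carbon gave a 22-fold lower number from compound 3 to compound 4 (1.34 log units; beyond the scatter), so the change did not carry over from one core to the other in size or direction: the same change on two cores in this assay, an 11-fold higher number (1.02 log units; beyond the scatter) from compound 1 to compound 2 and a 22-fold lower number (1.34 log units; beyond the scatter) from compound 3 to compound 4, 230-fold (2.37 log units) apart, beyond the scatter of two such steps

The two methyl groups stand at different places on different cores, and these steps do not separate the place of the methyl from the rest of the structure. Among the compounds shown here, they show only that the earlier step did not hold for this pair, and they set no rule for the series.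

The compounds shown leave open how an amine or a carboxylic acid on that aromatic carbon would read in this assay. Also open, from the compounds shown here alone, is whether a longer chain there would follow either step.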